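A few compounds are considered here, and "the series" means these few. Any claim that something is new, unique, unknown or untested is made for them only; others in the source may bear on it.

Measured so far, in an assay on isolated protein for inhibition of thyroid hormone receptor alpha (Homo sapiens), read by fluorescence polarization; a lower number here means a stronger inhibitor, a higher number a weaker inhibitor:
Compound 1 `CS(=O)(=O)c1ccc(C(=O)N2CCC(C(=O)N3CCN(c4ccc(F)cc4)CC3)CC2)cc1[N+](=O)[O-]` gives > 60000 nM, a limit of the assay.
Compound 2 `CS(=O)(=O)c1ccc(C(=O)NCC(=O)N(Cc2ccccc2)Cc2ccccc2)cc1[N+](=O)[O-]` gives 1700 nM.
Compound 3 `CN(CC(=O)N(Cc1ccccc1)Cc1ccccc1)C(=O)c1ccc(S(C)(=O)=O)c([N+](=O)[O-])c1` gives > 60000 nM, a limit of the assay.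

For the measured compounds named here, compound 2 therefore holds the only number in this assay; the other two values sit at the limit of > 60000 nM in this assay, at which 2 of the 3 values shown sit. Compound 4 `CN(Cc1ccccc1)C(=O)CNC(=O)c1ccc(S(C)(=O)=O)c([N+](=O)[O-])c1` differs from compound 2 by hydrogen in place of phenyl on a saturated chain carbon bound to an amide-type nitrogen, that is, benzyl to methyl on the tertiary amide. Going by the values given here, the single measured step, an at least 35-fold higher number from compound 2 to compound 3 (1.54 log units; beyond the scatter), concerns a different amide-type nitrogen and so bears on this change only loosely, but it shows that small alterations around the amides of the series can cost a great deal. Loss of a phenyl is expected to weaken binding, with a step of a 4.7-fold higher number from compound 2 to compound 4 (0.67 log units; beyond the scatter) expected. Compound 4 is estimated at 8000 nM, in the range 2000 nM to 60000 nM, and a limit rather than a number is a real possibility.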

Compound 4, half-maximal inhibitory concentration: > 60000 nM
Compound 4 was reported as a limit; the forecaster's own chance of this, stated with the estimate: 30%; at least 7.5-fold (0.87 log units) between middle value and limit.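

In this assay, going from benzyl to methyl on the tertiary amide gives an at least 35-fold higher number from compound 2 to compound 4 (1.54 log units; beyond the scatter); compound 4 is a limit of the assay, so this step is a lower bound. The phenyl on that saturated chain carbon is therefore required for a measurable value within the compounds shown. Compound 2 remains the only compound with a number: the limit of > 60000 nM in this assay, at which 3 of the 4 values shown sit.

Open, going by these compounds, is whether a cyclohexylmethyl group or a longer chain such as phenylethyl at this place keeps a number in this assay. That would tell whether the phenyl itself is what counts.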